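Metabolic stability notes on a quinolone-acid series

The source may report more compounds than this note shows. Statements on the series, on what has been measured and on what is new or still open speak of the compounds shown alone.

Measured compounds:
compound 1 `CC(C)[C@@H](CO)n1cc(C(=O)O)c(=O)c2cc(Cc3cccc(Cl)c3F)cnc21` — 99%
compound 2 `CC[C@@H](CO)n1cc(C(=O)O)c(=O)c2cc(Cc3cccc(Cl)c3F)c(OC)nc21` — "not determined" (no result reported)

Among the compounds with values here, compound 1 stands as the only compound with a number in an ADME assay on microsomes from liver (Homo sapiens) for metabolic stability, with a stated time of 30 min; a lower number here means that less of the compound is left, a higher number that more of the compound is left; in this assay compound 1 gives 99%, which leaves almost all of the compound intact after the incubation. Within the data shown here, compound 2 carries the shared core with a methoxy group added and an ethyl branch at the hydroxymethyl-bearing chain carbon; for compound 2 this assay records "not determined" (no result reported), so compound 2 stands without a number of its own and no step between it and compound 1 can be read.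

Compound 3 `COc1nc2c(cc1Cc1cccc(Cl)c1F)c(=O)c(C(=O)O)cn2[C@H](CO)CC(C)C` is the next member, to be measured in this assay. The change from compound 2 to compound 3 is isopropyl in place of methyl on a saturated chain carbon, two bonds along the chain from an aromatic nitrogen. Among the measured compounds shown here, no measured step of this kind exists in the set, so the size and direction of the change cannot be taken from the data; the only anchor is the high value of compound 1, which suggests the core itself is well retained in this assay.

For compound 3 the expected result in this assay is 85%, within a range of 60% to 99%.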

Compound 3, percent of the compound remaining: 92%
Estimate against measurement, compound 3: 7 percentage points below, within the range that was stated.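

Within the data shown here, with compound 2 at "not determined" (no result reported) in this assay, no step to compound 3 can be read, and compound 3 at 92% differs from compound 1 in more than one place. The compounds shown leave open how isopropyl in place of methyl on the chain shifts the percent remaining. No evidence bears on the result of compound 3.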